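This account rests on a few compounds, and the source may have more. Where it says the series, first, only, none or still open, it means among the compounds named here.

Measured in a functional assay on MDA-MB-231 cells (Homo sapiens) for inhibition, with a stated time of 72 h; on this read-out lower numbers stand for stronger inhibition and higher numbers for weaker inhibition:
Compound 1 `O=C(Nc1ccccc1)Nc1nc(Sc2c[nH]c3ccccc23)cc(N2CCCC2)n1`: 7890 nM
Compound 2 `Cc1cc(Cl)ccc1NC(=O)Nc1nc(Nc2ccccc2)cc(Sc2c[nH]c3ccccc23)n1`: 17100 nM

In this assay compound 2 gives the highest number of the two, with compound 1 giving a lower number beyond the usual scatter. Compound 3 `Cc1cc(Cl)ccc1NC(=O)Nc1nc(Sc2c[nH]c3ccccc23)cc(N2CCCC2)n1` carries the change (pyrrolidin-1-yl in place of anilino on an aromatic carbon), pyrrolidin-1-yl in place of anilino on an aromatic carbon. Among the compounds with values here, no single-change step is measured for this change, so the expectation rests on compound 1, whose value 7890 nM lies below that of compound 2. Compound 3 is therefore expected to move a 1.9-fold lower number from compound 2 to compound 3 (0.28 log units; within the scatter), toward a lower number, and is estimated at 9000 nM, within 3000 nM to 27000 nM.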

Compound 3, half-maximal inhibitory concentration: 9440 nM
For compound 3 the middle estimate is 1.0-fold (0.02 log units) below the measured one; the range from low to high includes it.
By their numbers in this assay, from the lowest: compounds 1, 3 and 2 (each within the scatter of the next, the first and the last beyond it).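

In this assay, pyrrolidin-1-yl in place of anilino on this aromatic carbon gives a 1.8-fold lower number from compound 2 to compound 3 (0.26 log units; within the scatter), so with the 4-chloro-2-methylphenyl urea held constant, this change has no effect that can be told from the scatter. The other single change, 4-chloro-2-methylphenyl in place of phenyl on the amide-type nitrogen, gives a 1.2-fold higher number from compound 1 to compound 3 (0.08 log units; within the scatter), which also lies within the scatter. Neither change therefore separates these compounds.

On these data alone, whether morpholin-4-yl or piperidin-1-yl at this position would shift the number beyond the scatter stays open. Nothing available accounts for these small steps.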